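Working notes: methyl to ethyl in the series

The source may hold more compounds than are shown below. What is called first, only, known or untested is meant among the compounds shown, and "the series" means these compounds.

Measured in a functional assay on A-375 cells (Homo sapiens) for antiproliferative activity, read by MTT assay, with a stated time of 24 h; on this read-out lower numbers stand for stronger inhibition and higher numbers for weaker inhibition:
- compound 1 `CCc1ccc2nc(C(=O)Nc3c(F)cc(-c4cccc(F)c4)cc3F)c(C)c(O)c2c1`: 8130 nM
- compound 2 `Cc1ccc2nc(C(=O)Nc3c(F)cc(-c4cccc(F)c4)cc3F)c(C)c(C(=O)O)c2c1`: 26000 nM

Compound 2 at 26000 nM holds the higher of the two numbers, so it is the weaker inhibitor here. Compound 1 at 8130 nM lies lower, and the gap is beyond the usual scatter.

The next entry is compound 3 `CCc1ccc2nc(C(=O)Nc3c(F)cc(-c4cccc(F)c4)cc3F)c(C)c(C(=O)O)c2c1`, which differs from compound 2 by methyl in place of hydrogen on a saturated chain carbon bound to an aromatic carbon. This is methyl in place of hydrogen on a saturated chain carbon bound to an aromatic carbon, so methyl to ethyl.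

For the measured compounds named here, no measured pair differs in one place only, so the size of this change in this assay has not been seen. The estimated step of a 1.3-fold lower number from compound 2 to compound 3 (0.11 log units; within the scatter) is expected to stay within the scatter, leaning slightly towards a lower number. For compound 3 the expected value is 20000 nM, with an estimated range of 9000 nM to 45000 nM.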

Compound 3, half-maximal inhibitory concentration: 57800 nM
The estimate for compound 3 lay 2.9-fold (0.46 log units) below the measured number; measured number outside the range, above it.
By their numbers in this assay, from the lowest: compound 1; then compound 2; then compound 3.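

In this assay, for the compounds shown here, the saturated chain carbon bound to an aromatic carbon proves sensitive: methyl to ethyl there gives a 2.2-fold higher number from compound 2 to compound 3 (0.35 log units; beyond the scatter) with the rest of the structure unchanged, the first single-place reading at this position. With ethyl held in place, carboxy in place of hydroxy on an aromatic carbon gives a 7.1-fold higher number from compound 1 to compound 3 (0.85 log units; beyond the scatter) and so also moves towards weaker inhibition. Going by these compounds alone, both steps into compound 3 therefore point the same way, and the series so far offers no single-place change that lowers the number. No accompanying data explain either step.

From the compounds shown here alone, whether methyl to ethyl has the same effect when hydroxy replaces carboxy remains open. So does the outcome with a longer chain such as propyl at this place, or with an amine in place of carboxy on the aromatic carbon.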